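Bromo to Chloro on the Meta Position of Compound 3

The compounds below may be only part of what the source reports. "The series", "measured", "known", "first", "only" and "open" are said of these compounds alone.

Three thiosemicarbazones of a shared core have been measured in a functional assay on SGC-7901 cells (Homo sapiens) for antiproliferative activity, read by sulforhodamine B assay, with a stated time of 72 h; a higher number here means a weaker inhibitor, a lower number a stronger inhibitor. Compound 2 `CN(C)C(=S)N/N=C/c1ccc2cccnc2n1` gives 630 nM, compound 1 `FC(F)(F)c1ccccc1NC(=S)N/N=C/c1ccc2ccccc2n1` gives 20700 nM, and compound 3 `S=C(N/N=C/c1ccc2ccccc2n1)Nc1cccc(Br)c1` gives 78600 nM. Among these three numbers compound 3 stands highest: its nearest neighbour is compound 1, whose number lies lower by a margin beyond the scatter, and its furthest is compound 2, lower again by a margin well beyond the scatter. Among the compounds with values here, no two of the measured compounds differ from each other in a single place, so no measured step guides the next move directly.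

Compound 4 `S=C(N/N=C/c1ccc2ccccc2n1)Nc1cccc(Cl)c1` differs from compound 3 in one place: chloro in place of bromo on an aromatic carbon. A swap of one halogen for another at the same aromatic carbon is a small change, and in this assay the account expects a step from compound 3 to compound 4 of a 1.3-fold lower number from compound 3 to compound 4 (0.12 log units; within the scatter), that is, nothing clearly beyond the scatter in either direction. Compound 4 is therefore estimated at 60000 nM, with a range from 20000 nM to 180000 nM.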

Compound 4, half-maximal inhibitory concentration: 61300 nM
For compound 4 the middle estimate is 1.0-fold (0.01 log units) below the measured one; measured number inside the range.
By their numbers in this assay, from the lowest: compound 2; then compound 1; then compounds 4 and 3 (each within the scatter of the next).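

Chloro in place of bromo on an aromatic carbon gives the only single-place step in this set. In this assay, within the data shown here, that step reads a 1.3-fold lower number from compound 3 to compound 4 (0.11 log units; within the scatter), so at this position the two halogens cannot be told apart, something the earlier compounds, which all differ in more than one place, could not show. Nothing available speaks to a reason for this result.

The compounds shown leave open whether a group other than a halogen on this same aromatic carbon, such as an amine, a methoxy group or a carboxylic acid, would give a step beyond the scatter. They also leave open whether the same exchange of bromo for chloro would read alike on another carbon of this six-membered aromatic ring.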